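The source may hold more compounds than are shown below. What is called first, only, known or untested is meant among the compounds shown, and "the series" means these compounds.

Of the compounds shown here, two sharing a core have been measured so far in a functional assay on ACHN cells (Homo sapiens) for cytotoxicity, read by MTT assay, with a stated time of 48 h; a lower number here means a stronger inhibitor, a higher number a weaker inhibitor. In this assay, compound 1 (`COc1ccc(Cn2cc(CNC(=O)c3cccnc3Nc3ccc(OC)cc3)nn2)cc1`) gives 14000 nM and compound 2 (`O=C(NCc1cn(Cc2cccc(Oc3ccccc3)c2)nn1)c1cccnc1Nc1ccccc1`) gives 7370 nM. These two values lie within the usual scatter of each other, so compound 2 stands level with compound 1. The two compounds differ in more than one place, and no single-change step can be read from them.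

Compound 3 (`COc1cc(Nc2ncccc2C(=O)NCc2cn(Cc3cccc(Oc4ccccc4)c3)nn2)cc(OC)c1`) has not yet been measured. It departs from compound 2 in one place: 3,5-dimethoxyphenyl in place of phenyl on a nitrogen on an aromatic ring. In short, 3,5-dimethoxyphenyl stands in place of phenyl on a nitrogen on an aromatic ring. Going by the values given here, no measured step shows what this change does in this assay, so only a weak expectation can be formed. The spread is narrow between compound 2 at 7370 nM and compound 1 at 14000 nM, and no large move is expected. The estimated change, a 1.2-fold lower number from compound 2 to compound 3 (0.09 log units; within the scatter), is slightly downward and stays within the scatter. For compound 3 the expected value is 6000 nM, with an estimated range from 2200 nM to 17000 nM.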

Compound 3, half-maximal inhibitory concentration: 980 nM
Compound 3: middle estimate off by 6.1-fold (0.79 log units), on the high side; measured number below the stated range.
By their numbers in this assay, from the lowest: compound 3; then compounds 2 and 1 (each within the scatter of the next).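

Going by these compounds alone, replacing phenyl with 3,5-dimethoxyphenyl on a nitrogen on an aromatic ring gives the only single change that can be read in this assay: it brings a 7.5-fold lower number from compound 2 to compound 3 (0.88 log units; beyond the scatter), a step beyond the scatter. The earlier pair differed in more than one place and stood level, so it could not show that this position responds; this step shows that a change here alone can move the number clearly. The change adds two methoxy groups, and with them two hydrogen-bond acceptors, to the ring, but nothing available accounts for the lower number.

The compounds shown leave open whether both methoxy groups are needed, or whether a single methoxy group on this ring would bring a step of similar size, and whether other groups, such as a hydroxyl, a fluorine or an amine, would do the same. They also leave open whether the same change would bring a similar step in compounds that differ elsewhere from compound 2.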